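The source may report more compounds than this note shows. Statements on the series, on what has been measured and on what is new or still open speak of the compounds shown alone.

Working notes on a series sharing one core, followed in a functional assay on HepG2 cells (Homo sapiens) for cytotoxicity, read by MTT assay, with a stated time of 24 h; on this read-out lower numbers stand for stronger inhibition and higher numbers for weaker inhibition. Compound 1 (`COc1cc(/C=C2\CN(C)C/C(=C\c3ccc(Br)cc3)C2=O)cc(OC)c1`) gives 4840 nM, and compound 2 (`COc1cc(/C=C2\CN(C)C/C(=C\c3ccc(Cl)cc3Cl)C2=O)cc(OC)c1`) gives 6250 nM. Within the data shown here, these two values lie within the scatter of each other, so compound 2 stands level with the only other measured compound.

The unmeasured compound 3 (`COc1cc(/C=C2\CN(C)C/C(=C\c3ccc(Cl)c(Cl)c3)C2=O)cc(OC)c1`) differs from compound 2 as follows: 3,4-dichlorophenyl in place of 2,4-dichlorophenyl on a double-bonded chain carbon bound to a double-bonded ring carbon. The change sits on a double-bonded chain carbon bound to a double-bonded ring carbon, the same place that differs between the two measured compounds.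

Among the measured compounds shown here, one measured step bears on it: a 1.3-fold higher number from compound 1 to compound 2 (0.11 log units; within the scatter). For the measured compounds named here, that step stayed within the scatter, and it is the only evidence available. Going by the values given here, no measured pair compares 2,4-dichlorophenyl with 3,4-dichlorophenyl directly. In this assay, no step beyond the scatter is therefore expected, and no direction is favoured.

The estimated step is a 1.1-fold lower number from compound 2 to compound 3 (0.06 log units; within the scatter). For compound 3 the expected value is 5500 nM, with an estimated range of 2800 nM to 11000 nM.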

Compound 3, half-maximal inhibitory concentration: 3840 nM
Estimate against measurement, compound 3: 1.4-fold (0.16 log units) above; the measured number falls inside the stated range.
By their numbers in this assay, from the lowest: compounds 3, 1 and 2 (each within the scatter of the next).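

In this assay, the place on a double-bonded chain carbon bound to a double-bonded ring carbon now has its first direct comparison of two dichlorophenyl groups with the same atoms joined differently. Putting 3,4-dichlorophenyl in place of 2,4-dichlorophenyl gives a step within the scatter (a 1.6-fold lower number from compound 2 to compound 3 (0.21 log units; within the scatter)), so this rearrangement of the two chlorines does not separate the compounds here, and putting 3,4-dichlorophenyl in place of 4-bromophenyl also stays within the scatter (a 1.3-fold lower number from compound 1 to compound 3 (0.10 log units; within the scatter)). All three compounds therefore stand level, with no group at this place set apart, and no measurement at hand offers an explanation for this flat picture.

From the compounds shown here alone, all three groups at this place are halogen-bearing phenyl rings, so it remains open whether a phenyl ring carrying an amine or a carboxylic acid, or a pyridine ring in its place, would give a step beyond the scatter. The rest of the structure is the same across compounds 1, 2 and 3, which leaves the effect of changes elsewhere on the shared core open as well.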